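The compounds below may be only part of what the source reports. "The series", "measured", "known", "first", "only" and "open" are said of these compounds alone.

Compound 1 `COc1ccc(-c2nc(C)c(C(=O)CSc3nc(-c4ccc(OC)cc4)c(C#N)c(=O)[nH]3)s2)cc1` gives 80.3%
Compound 2 `COc1ccc(-c2nc(C)c(C(=O)CSc3nc(-c4ccc(Cl)c(Cl)c4)c(C#N)c(=O)[nH]3)s2)cc1` gives 88.6%
Compound 3 `COc1ccc(-c2nc(C)c(C(=O)CSc3nc(-c4cccc(OC)c4)c(C#N)c(=O)[nH]3)s2)cc1` gives 66.7%

Of the compounds shown here, three built on one shared core have been measured in a functional assay on U-87MG ATCC cells for antiproliferative activity against U-87 MG (Homo sapiens), read by MTT assay, with a stated time of 48 h, tested at 10 uM; on this read-out higher numbers stand for a weaker effect at the one concentration tested and lower numbers for a stronger effect. Compound 2 stands at the highest of the three numbers. Its nearest neighbour is compound 1, reached by a number 8.3 percentage points higher from compound 1 to compound 2 (within the scatter), a step that lies within the scatter. Its furthest neighbour is compound 3, reached by a number 21.9 percentage points lower from compound 2 to compound 3 (beyond the scatter), which lies beyond the scatter. The remaining step, a number 13.6 percentage points lower from compound 1 to compound 3 (beyond the scatter), also lies beyond the scatter. All three measured steps exchange one aryl group at the same place on the shared core.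

Compound 4 `Cc1nc(-c2ccccc2)sc1C(=O)CSc1nc(-c2ccc(Cl)c(Cl)c2)c(C#N)c(=O)[nH]1` is reached from compound 2 by a change at a different place: hydrogen in place of methoxy on an aromatic carbon. Among the compounds with values here, none of the measured steps touches the methoxy group that leaves here, so no measured step bears directly on this change. Within the data shown here, the only guide is that the measured numbers of all three compounds sit in a fairly narrow band, and compound 4 keeps the 3,4-dichlorophenyl group of compound 2 unchanged. The step is therefore expected to fall within the scatter, with no clear direction. Compound 4 is estimated at 84%, in a range from 68% to 98%. The expected step from compound 2 is a number 4.6 percentage points lower from compound 2 to compound 4 (within the scatter).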

Compound 4, a percentage reported as activity, at one concentration (the size of the read-out at that concentration, not a potency): 92.5%
For compound 4 the middle estimate is 8.5 percentage points below the measured one; the range from low to high includes it.
By their numbers in this assay, from the lowest: compound 3; then compounds 1, 2 and 4 (each within the scatter of the next, the first and the last beyond it).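

In this assay, the exchange of 4-methoxyphenyl for phenyl, with hydrogen in place of methoxy on an aromatic carbon para to a large group, comes to a number 3.9 percentage points higher from compound 2 to compound 4 (within the scatter). Within the data shown here, this is the first measured step at this place on the shared core, and it shows that, with the 3,4-dichlorophenyl group held constant, the methoxy group can be lost without a difference beyond the usual scatter, whereas two of the three earlier steps, both exchanges of the other aryl group, went beyond it. Nothing measured here gives a reason for this result, and a single pair cannot show whether this place is generally tolerant of change.

The compounds shown do not tell whether the same exchange would read the same way in compound 3, which carries the 3-methoxyphenyl group and has the lowest number of the set. Among these compounds, they also leave open what a dimethylamino group, a carboxylic acid or a longer chain such as butoxy would do at this place, since hydrogen and methoxy are the only two groups seen there.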